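The source may report more compounds than this note shows. Statements on the series, on what has been measured and on what is new or still open speak of the compounds shown alone.

Compound 1, `O=C1C(Nc2cccc(Cl)c2)=CC(=O)c2c1nc1n2[C@H]2OC[C@@H](O)[C@H]2OC1`: 1530 nM
Compound 2, `COc1ccc(NC2=CC(=O)c3c(nc4n3[C@H]3OC[C@@H](O)[C@H]3OC4)C2=O)cc1`: 2150 nM
Compound 3, `O=C1C(NC2CCCC2)=CC(=O)c2c1nc1n2[C@H]2OC[C@@H](O)[C@H]2OC1`: a limit, > 16000 nM

All three were tested in a functional assay on MGC-803 cells (Homo sapiens) for inhibition, read by sulforhodamine B assay; a higher number here means a weaker inhibitor, a lower number a stronger inhibitor. Among the compounds with values here, compound 3 is the one compound that gave no number, only the limit of the assay, (the limit of > 16000 nM in this assay, at which 1 of the 3 values shown sits). Compound 4, `O=C1C(Nc2ccc(C(F)(F)F)cc2)=CC(=O)c2c1nc1n2[C@H]2OC[C@@H](O)[C@H]2OC1`, differs from compound 3 by 4-(trifluoromethyl)phenyl in place of cyclopentyl on an amine nitrogen. Within the data shown here, two measured steps bear on this change: an at least 10-fold higher number from compound 1 to compound 3 (1.01 log units; beyond the scatter) and an at least 7.4-fold higher number from compound 2 to compound 3 (0.87 log units; beyond the scatter), both beyond the scatter, both exchanging an aryl group on that amine nitrogen for cyclopentyl. Compound 4 runs that exchange backwards, so a strongly lower number is expected, estimated as an at least 8.0-fold lower number from compound 3 to compound 4 (0.90 log units; beyond the scatter). The two aryl analogues, compound 1 at 1530 nM and compound 2 at 2150 nM, lie within the scatter of each other. Compound 4 is therefore estimated at 2000 nM, with a range from 700 nM to 6000 nM.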

Compound 4, half-maximal inhibitory concentration: 1860 nM
Compound 4: the middle estimate sits 1.1-fold (0.03 log units) above what was measured; measured number inside the range.
By their numbers in this assay, from the lowest: compounds 1, 4 and 2 (each within the scatter of the next). At a limit, above all of these: compound 3.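

Read in this assay, 4-(trifluoromethyl)phenyl in place of cyclopentyl on the amine nitrogen gives an at least 8.6-fold lower number from compound 3 to compound 4 (0.93 log units; beyond the scatter). Compound 3 stands only at a limit: the limit of > 16000 nM in this assay, at which 1 of the 4 values shown sits. The three aryl groups do not separate, with a 1.2-fold lower number from compound 2 to compound 4 (0.06 log units; within the scatter) and a 1.2-fold higher number from compound 1 to compound 4 (0.08 log units; within the scatter), so among these compounds a 4-trifluoromethyl group on the ring serves like 4-methoxy or 3-chloro.

As far as these compounds go, it remains open whether an aryl ring carrying an amine or a carboxylic acid would stay with these three compounds. From the compounds shown here alone, it also remains open whether a longer open chain on that nitrogen would fall with cyclopentyl.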